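This account rests on a few compounds, and the source may have more. Where it says the series, first, only, none or still open, it means among the compounds named here.

Of the compounds shown here, three have so far been measured in an assay on isolated protein (Cavia porcellus) with Sigma non-opioid intracellular receptor 1 (Homo sapiens) as the target, read by radioligand binding; on this read-out higher numbers stand for weaker inhibition and lower numbers for stronger inhibition. Compound 1 `O=c1cc(-c2ccccc2)oc2cccc(OCCCCN3CCC(O)CC3)c12` gives 177 nM. Compound 2 `CN(C)CCCCCCCCOc1ccc2oc(-c3ccccc3)cc(=O)c2c1`, which shares the core but carries a different chain and a different amine, gives 143 nM. Compound 3 `O=c1cc(-c2cccnc2)oc2ccc(OCCCCCCN3CCC(O)CC3)cc12`, which carries a pyridin-3-yl group on the core, gives 210 nM. Among the three, compound 3 shows the largest number, but its gap to compound 1 and its gap to compound 2 both fall within the usual scatter of repeated measurements, so on these numbers the three compounds cannot be told apart.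

Compound 4 `O=c1cc(-c2ccncc2)oc2ccc(OCCCCCCN3CCC(O)CC3)cc12` has not yet been measured. It differs from compound 3 in a single place: pyridin-4-yl in place of pyridin-3-yl on an aromatic carbon. The two compounds are built from the same atoms, joined differently.

Among the compounds with values here, no measured pair shows what such a change does here, so there is no step to lean on. Since the three measured compounds sit within the scatter of one another despite larger differences in their chains and amines, the change from compound 3 to compound 4 is expected to be small, and a 1.1-fold higher number from compound 3 to compound 4 (0.04 log units; within the scatter) is expected to stay within the scatter, in either direction. Compound 4 is therefore estimated at 230 nM, with a range from 90 nM to 600 nM.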

Compound 4, half-maximal inhibitory concentration: 308 nM
For compound 4 the middle estimate is 1.3-fold (0.13 log units) below the measured one; the measured number falls inside the stated range.
By their numbers in this assay, from the lowest: compounds 2, 1, 3 and 4 (each within the scatter of the next, the first and the last beyond it).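

Within the data shown here, this is the first pair here that differs in one place only, so it gives the first direct reading of a change at this position, the aromatic carbon next to the ring oxygen of the shared core: in this assay, putting pyridin-4-yl in place of pyridin-3-yl gives a 1.5-fold higher number from compound 3 to compound 4 (0.17 log units; within the scatter), a step between two compounds built from the same atoms. Since that step lies within the usual scatter of repeated measurements, compound 3 and compound 4 cannot be told apart, and on this one pair the read-out does not register where the nitrogen sits in the pyridine ring. Nothing further is at hand that would explain the numbers for this pair.

On these data alone, what a phenyl or a pyridin-2-yl group would give at this same carbon, with the rest of compound 3 unchanged, stays open. So does whether a group of a different kind there, such as a carboxylic acid or a dimethylamino group, would carry the number beyond the scatter, which would show that this position matters at all for this read-out.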